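Replacing the Propargyl Group With a Fluorophenyl Ketone

The source may hold more compounds than are shown below. What is called first, only, known or untested is meant among the compounds shown, and "the series" means these compounds.

Three compounds sharing one core were tested in a functional assay on PC-3M cells (Homo sapiens) for cytotoxicity, read by MTT assay, with a stated time of 48 h; a lower number here means a stronger inhibitor, a higher number a weaker inhibitor. Compound 1 `CSc1nnc(C)n1N1C(=O)c2ccccc2C1=O` gives only a limit, > 200000 nM. Compound 2 `CCc1nnc(SC)n1N1C(=O)c2ccccc2C1=O` likewise gives only a limit, > 200000 nM. The step that the two limits leave unreadable from compound 1 to compound 2 therefore cannot be read. Compound 3 `C#CCSc1nnc(-c2cc(OC)c(OC)c(OC)c2)n1N1C(=O)c2ccccc2C1=O` also reaches only a limit, > 200000 nM. Among the compounds with values here, all three thus sit at the limit of > 200000 nM in this assay, at which 3 of the 3 values shown sit, and nothing measured so far separates them. Compound 4 `COc1cc(-c2nnc(SCC(=O)c3ccc(F)cc3)n2N2C(=O)c3ccccc3C2=O)cc(OC)c1OC` differs from compound 3 by (4-fluorophenyl)carbonyl in place of ethynyl on a saturated chain carbon bound to a sulfur. Within the data shown here, no measured step covers this kind of change, and the single step available is unreadable. Compound 4 is expected to stay near that same limit, with the step of an at least 1.3-fold lower number from compound 3 to compound 4 (0.12 log units; that floor lies within the scatter) estimated to be small, giving an estimated 150000 nM within 30000 nM to 300000 nM.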

Compound 4, half-maximal inhibitory concentration: > 200000 nM
Compound 4: a limit, no number (the forecaster's own chance of this, stated with the estimate: 60%); middle value at least 1.3-fold (0.12 log units) from the limit.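

Within the data shown here, compound 3 and compound 4 each give only a limit in this assay, so no step between them can be read. The compounds shown leave open whether any member of this series gives a readable number: the limit of > 200000 nM in this assay, at which 4 of the 4 values shown sit.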